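What Two Methyl Groups Might Do to Compound 3

A few compounds are considered here, and "the series" means these few. Any claim that something is new, unique, unknown or untested is made for them only; others in the source may bear on it.

Three measured compounds share one core and differ only in how a 2,6-dichlorophenyl ring is attached to it. Compound 1 `O=C(Nc1ccc(C(F)(F)F)cc1)c1csc(Cc2c(Cl)cccc2Cl)n1` carries a 2,6-dichlorobenzyl group, and in an assay on CHO cells, read by calcium flux (a lower number here means a stronger inhibitor, a higher number a weaker inhibitor), compound 1 gives 88 nM. Compound 2 `O=C(Nc1ccc(C(F)(F)F)cc1)c1csc(Oc2c(Cl)cccc2Cl)n1`, with a 2,6-dichlorophenoxy group, gives 1280 nM in this assay, a 15-fold higher number from compound 1 to compound 2 (1.16 log units; beyond the scatter). Compound 3 `O=C(Nc1ccc(C(F)(F)F)cc1)c1csc(Nc2c(Cl)cccc2Cl)n1`, with a (2,6-dichlorophenyl)amino group, gives 48 nM in this assay. That is the lowest of the three numbers, though a 1.8-fold lower number from compound 1 to compound 3 (0.26 log units; within the scatter) is within the scatter, while a 27-fold lower number from compound 2 to compound 3 (1.43 log units; beyond the scatter) is a large step.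

Compound 4 `Cc1cccc(C)c1Nc1nc(C(=O)Nc2ccc(C(F)(F)F)cc2)cs1` keeps the linking nitrogen of compound 3 and changes only the ring it carries: 2,6-dimethylphenyl in place of 2,6-dichlorophenyl on a nitrogen on an aromatic ring. None of the three measured steps bears on this ring; all of them concern the link, so they give no direction for the new change. With nothing in the data pulling either way, the expectation for compound 4 is a step no larger than the scatter, an estimated 1.5-fold higher number from compound 3 to compound 4 (0.16 log units; within the scatter). Compound 4 is therefore expected to give about 70 nM in this assay, within a range from 20 nM to 250 nM.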

Compound 4, half-maximal inhibitory concentration: 82 nM
Beside the measured number, compound 4's estimate is 1.2-fold (0.07 log units) below it, within the range that was stated.
By their numbers in this assay, from the lowest: compounds 3, 4 and 1 (each within the scatter of the next); then compound 2.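

In this assay, among the compounds shown here, 2,6-dimethylphenyl in place of 2,6-dichlorophenyl on the linking nitrogen gives a 1.7-fold higher number from compound 3 to compound 4 (0.23 log units; within the scatter) and so offers the only reading here of a change to the ring itself, since the earlier steps concerned only the link; at this position, two methyl groups and two chlorines cannot be told apart by this measurement. The large penalty of the oxygen link also stands against the new ring, with (2,6-dimethylphenyl)amino in place of 2,6-dichlorophenoxy giving a 16-fold lower number from compound 2 to compound 4 (1.19 log units; beyond the scatter) in the same measurement. The carbon link stays as close to the new ring as it did to the dichloro ring, as (2,6-dimethylphenyl)amino in place of 2,6-dichlorobenzyl gives a 1.1-fold lower number from compound 1 to compound 4 (0.03 log units; within the scatter) and leaves these two compounds inseparable as well.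

As far as these compounds go, it remains open whether this tolerance reaches other groups on the ring, such as plain phenyl with no added groups, 2,6-difluorophenyl or 2,6-dimethoxyphenyl, or whether it holds only for this pair. Nothing shown here explains why the two rings read alike.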